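The compounds below may be only part of what the source reports. "The series", "measured", "known", "first", "only" and "open" are said of these compounds alone.

Series notes, all values from a functional assay on U-373MG ATCC cells (Homo sapiens) for inhibition, read by MTT assay, with a stated time of 72 h; a higher number here means a weaker inhibitor, a lower number a stronger inhibitor:

- compound 1 `CC1(C)CC(NC(=O)Nc2cccc(Cl)c2)c2cc(Br)ccc2O1`: 69000 nM
- compound 2 `CC1(C)CC(NC(=O)Nc2ccccc2)c2cc(Cl)ccc2O1`: 68000 nM
- compound 3 `COc1ccccc1NC(=S)NC1CC(C)(C)Oc2ccc(Br)cc21`: 22000 nM

Compound 2 at 68000 nM sits level with compound 1 at 69000 nM, the two lying within the scatter of each other. Compound 3 at 22000 nM gives a lower number than compound 2, and that gap lies beyond the scatter. With only these three values, the series covers a narrow range.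

The next compound to be read is compound 4 `CCNC(=O)NC1CC(C)(C)Oc2ccc(Cl)cc21`, which departs from compound 2 as follows: ethyl in place of phenyl on an amide-type nitrogen. This places ethyl in place of phenyl on an amide-type nitrogen. For the measured compounds named here, no pair of measured compounds differs in one place only, so the data hold no direct precedent for this change. Every measured compound also retains a phenyl-type group at that nitrogen, so the ethyl compound lies outside what has been sampled.

The starting point is compound 2 at 68000 nM, and a shift toward weaker inhibition is expected, though with wide uncertainty. The expected change is a 2.2-fold higher number from compound 2 to compound 4 (0.34 log units; beyond the scatter), a step of modest size. For compound 4 the estimated value is 150000 nM, with an expected range of 50000 nM to 400000 nM.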

Compound 4, half-maximal inhibitory concentration: > 100000 nM
Compound 4 was reported as a limit; the forecaster's own chance of this, stated with the estimate: 35%; the middle value does not contradict the limit.
By their numbers in this assay, from the lowest: compound 3; then compounds 2 and 1 (each within the scatter of the next). At a limit, above all of these: compound 4.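

In this assay compound 4 gives > 100000 nM, which is a limit and not a number. For the compounds shown here, this is the only one-place step and the only reading without a phenyl-type group on the amide-type nitrogen: ethyl in place of phenyl gives an at least 1.4-fold higher number from compound 2 to compound 4 (0.16 log units; that floor lies within the scatter). As far as these compounds go, the change therefore brings no measurable gain at this position, but the floor alone does not separate compound 4 from compound 2, and the true size of the step remains unknown, with the reading resting at the limit: the limit of > 100000 nM in this assay, at which 1 of the 4 values shown sits.

Open at this nitrogen is whether a longer chain such as butyl, or a saturated ring such as cyclohexyl, reads closer to the phenyl of compound 2 or to the ethyl of compound 4. Also open, from the compounds shown here alone, is what underlies the number of compound 3 at 22000 nM, since that compound differs from compound 2 in more than one place and a thiourea carrying an unsubstituted phenyl on the same core would be needed to isolate any single change.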